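The compounds below may be only part of what the source reports. "The series", "measured", "known", "first", "only" and "open" are said of these compounds alone.

Measured compounds:
- compound 1, `O=C(CN1CCN(c2ccc(F)cn2)CC1)Nc1nc2c(o1)CCCC2`: 2.7
- compound 2, `O=C(CN1CCN(c2cccc(F)c2)CC1)Nc1nc2c(s1)CCCC2`: "not determined" (no result reported)
- compound 3, `O=C(CN1CCN(c2ccc(F)cc2)CC1)Nc1nc2c(o1)CCCC2`: 3

For the measured compounds named here, in a physicochemical assay for lipophilicity, in phosphate buffer, measured as octanol-water partition, at pH 7.4 (on this read-out higher numbers stand for higher lipophilicity and lower numbers for lower lipophilicity), compound 1 gives 2.7 and compound 3 gives 3; the one step between them, a number 0.30 log units higher from compound 1 to compound 3 (within the scatter), is small. Going by the values given here, for compound 2 the outcome in this assay is "not determined" (no result reported), so compound 2 stands nowhere on the numbers: it has no value of its own and no step connects it to compound 1 or compound 3, which differ from it in the core as well as in the group on the piperazine.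

Compound 4, `O=C(CN1CCN(c2ccccn2)CC1)Nc1nc2c(s1)CCCC2`, is still to be measured. The change from compound 2 to compound 4 is pyridin-2-yl in place of 3-fluorophenyl on an amine nitrogen in a ring.

Among the compounds with values here, the only measured step bearing on this change is the one from compound 1 to compound 3: it also exchanges a fluorophenyl for a fluoropyridin-2-yl on the same ring nitrogen, in the opposite direction, and it stayed within the scatter. The present change goes further, as the fluorine leaves and nothing replaces it. A shift downward of modest size, possibly still within the scatter, is therefore expected. For compound 4 the value in this assay is estimated at 3, with a range from 2.5 to 3.5.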

Compound 4, distribution coefficient: 3.9
The estimate for compound 4 lay 0.90 log units below the measured number, outside the stated range (above it).
By their numbers in this assay, from the lowest: compounds 1 and 3 (each within the scatter of the next); then compound 4.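

In this assay compound 4 gives 3.9 but no step can be read from it, since compound 2 has no number to compare. Still open, as far as these compounds go, is how pyridin-2-yl in place of 3-fluorophenyl shifts lipophilicity on this core. No evidence shown bears on this result.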